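The source may hold more compounds than are shown below. What is called first, only, known or untested is meant among the compounds shown, and "the series" means these compounds.

Measured in a functional assay on NCI-H460 cells (Homo sapiens) for inhibition, read by MTT assay, with a stated time of 48 h; on this read-out lower numbers stand for stronger inhibition and higher numbers for weaker inhibition:
- Compound 1 `O=C(CC(c1ccccc1)C(C(=O)Nc1ccccn1)C(=O)Nc1ccccn1)c1ccccc1`: "not active" (no number reported)
- Compound 2 `O=C(CC(c1ccc(Cl)cc1)C(C(=O)Nc1ccccn1)C(=O)Nc1ccccn1)c1ccccc1`: 18900 nM
- Compound 3 `O=C(CC(c1ccc(Cl)cc1Cl)C(C(=O)Nc1ccccn1)C(=O)Nc1ccccn1)c1ccccc1`: 13100 nM

Within the data shown here, compound 3 and compound 2 are the only compounds with numbers, and the two cannot be told apart. Compound 4 `Cc1cc(C)c(C(CC(=O)c2ccccc2)C(C(=O)Nc2ccccn2)C(=O)Nc2ccccn2)c(C)c1` carries 2,4,6-trimethylphenyl in place of 2,4-dichlorophenyl on a saturated chain carbon bound to two saturated chain carbons. Among the measured compounds shown here, the one measured step nearby is a 1.4-fold lower number from compound 2 to compound 3 (0.16 log units; within the scatter), and no measured step involves methyl groups. So no shift beyond the scatter is expected in this assay. Compound 1 gives "not active" (no number reported), so compound 4, which also lacks chlorine, may give no number at all. The expected change is a 1.4-fold higher number from compound 3 to compound 4 (0.14 log units; within the scatter). For compound 4 the estimated value is 18000 nM, with an expected range from 7000 nM to 45000 nM.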

Compound 4, half-maximal inhibitory concentration: 23200 nM
Estimate against measurement, compound 4: 1.3-fold (0.11 log units) below, within the range that was stated.
By their numbers in this assay, from the lowest: compounds 3, 2 and 4 (each within the scatter of the next).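

In this assay, 2,4,6-trimethylphenyl on this saturated chain carbon gives a 1.8-fold higher number from compound 3 to compound 4 (0.25 log units; within the scatter) and also a 1.2-fold higher number from compound 2 to compound 4 (0.09 log units; within the scatter) within the same sentence of comparison. Both steps lie within the scatter, so compound 4 shows that a number can be obtained here with a ring carrying methyl groups and no chlorine. No measurement available explains this likeness between the rings.

On these data alone, it remains open whether an amine or a carboxylic acid on this ring would shift the number beyond the scatter. The same question stands for a longer chain at this position.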